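The compounds below may be only part of what the source reports. "The series", "measured", "known", "first", "only" and "open" are said of these compounds alone.

Compound 1 `COc1cccc(OCCC(C)(C)C)c1C(=O)/C=C/c1ccc(O)cc1`: > 30000 nM, a limit of the assay rather than a number.
Compound 2 `O=C(/C=C/c1ccc(O)cc1)c1c(O)cccc1OCC1CCCC1`: 13000 nM.
Compound 3 `CC(C)(C)CCOc1cccc(O)c1C(=O)CCc1ccc(O)cc1`: > 30000 nM, again a limit of the assay.

Within the data shown here, in an assay on THP-1 cells for inhibition of nuclear factor NF-kappa-B complex (Homo sapiens), with stated times of 2 h and 16 h (on this read-out higher numbers stand for weaker inhibition and lower numbers for stronger inhibition), compound 2 stands alone as the one compound of the three for which a number was obtained; its value of 13000 nM is the only point of reference. Among the measured compounds shown here, two of the three results sit at the limit of > 30000 nM in this assay, at which 2 of the 3 values shown sit, so the measured range is thin, and no pair of compounds differing in a single place has been measured, which leaves the size of any step unknown from the data themselves.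

Compound 4 `CC(C)COc1cccc(O)c1C(=O)/C=C/c1ccc(O)cc1` differs from compound 2 in one place: isopropyl in place of cyclopentyl on a saturated chain carbon bound to an oxygen on an aromatic ring. For the measured compounds named here, with no measured step of this kind to lean on, the expectation for compound 4 is a step of a 1.5-fold higher number from compound 2 to compound 4 (0.19 log units; within the scatter) of modest size toward weaker inhibition, not far beyond the usual scatter. Compound 4 is therefore estimated at 20000 nM, within a range from 7000 nM to 60000 nM, with a real chance that this assay reports only a limit.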

Compound 4, half-maximal inhibitory concentration: 8000 nM
Beside the measured number, compound 4's estimate is 2.5-fold (0.40 log units) above it; low and high end bracket the measured number.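

In this assay, among these compounds, the exchange of cyclopentyl for isopropyl gives a 1.6-fold lower number from compound 2 to compound 4 (0.21 log units; within the scatter), the first step that can be read. At this place, on a saturated chain carbon bound to an oxygen on an aromatic ring, cyclopentylmethoxy and isobutoxy cannot be told apart, so the ring of carbon is not needed for a measurable number here. Compound 1 and compound 3 remain limits of the assay, so no step to either can be read: the limit of > 30000 nM in this assay, at which 2 of the 4 values shown sit.

Going by these compounds, whether a longer chain, a phenyl ring or an amine at this place would carry the number beyond the scatter stays open. So does whether a group of any kind here could bring the number far below those of compound 2 and compound 4.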